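Removing the chloro group from compound 1

The source may report more compounds than this note shows. Statements on the series, on what has been measured and on what is new or still open speak of the compounds shown alone.

Compound 1 `Cc1cc(C)nc(SCc2cc(=O)c3cc(Cl)ccc3o2)n1` is one of three compounds tested in a functional assay on SW480 cells (Homo sapiens) for cytotoxicity, read by MTT assay, with a stated time of 72 h; on this read-out higher numbers stand for weaker inhibition and lower numbers for stronger inhibition. For compound 1 this assay gives only a limit, > 25000 nM. Compound 2 `Cc1nnc(Sc2coc3ccccc3c2=O)s1` likewise reaches only a limit in this assay, > 50000 nM. Going by the values given here, compound 3 `Cc1cc(C)n2nc(SCc3nnc(SCc4coc5ccccc5c4=O)n3-c3ccccc3)nc2n1` gives 12400 nM in this assay, the sole numerical value among the three. Among the compounds with values here, compound 1 thus sits at a limit, next to one further limit, with no measured step joining it to any other compound. Compound 4 `Cc1cc(C)nc(SCc2cc(=O)c3ccccc3o2)n1` differs from compound 1 by hydrogen in place of chloro on an aromatic carbon. Within the data shown here, no measured pair shows such a change, so the step is estimated as none beyond the scatter: a step that the limit leaves unreadable from compound 1 to compound 4. Compound 4 is therefore expected to give about 30000 nM in this assay, between 12000 nM and 80000 nM, and quite possibly only a limit again.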

Compound 4, half-maximal inhibitory concentration: > 25000 nM
Compound 4: no number, only a limit (the forecaster's own chance of this, stated with the estimate: 65%); the middle value is on the limit's open side.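

In this assay compound 4 gives only a limit, > 25000 nM. Compound 1 likewise gives only a limit, > 25000 nM, and no step can be read between compound 1 and compound 4. On these data alone, whether hydrogen in place of chloro changes the cytotoxicity at all remains open.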